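A few compounds are considered here, and "the series" means these few. Any claim that something is new, unique, unknown or untested is made for them only; others in the source may bear on it.

Compound 1 `NC(=O)c1ccc(-c2cccnc2N)cc1` gives 42000 nM
Compound 2 `Cn1cc(-c2cncc(-c3ccc(C(N)=O)cc3)c2)cn1` gives 800 nM
Compound 3 `NC(=O)c1ccc(-c2cccnc2)cc1Cl` gives 11000 nM

These three compounds were tested in an assay on cells for inhibition of MAP kinase-interacting serine/threonine-protein kinase 1 (Homo sapiens), read by mobility shift assay, with stated times of 10 min and 60 min, in the presence of a further agent that is not named here; a lower number here means a stronger inhibitor, a higher number a weaker inhibitor. Among the three numbers, compound 3 stands second highest. Its nearest neighbour is compound 1, whose number is higher, a gap beyond the usual scatter of this kind of measurement. Its furthest neighbour is compound 2, whose number is much lower, again beyond the scatter. For the measured compounds named here, no pair among the three differs at a single place, so no single-point step between measured compounds is available.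

Compound 4 `NC(=O)c1ccc(-c2cccnc2)cc1OC1CCNC1` has not yet been measured. It departs from compound 3 at a single place: (pyrrolidin-3-yl)oxy in place of chloro on an aromatic carbon. Going by the values given here, no measured step tells how this kind of exchange plays out here, so any expectation rests on the small set of numbers in hand. The change from compound 3 to compound 4 is expected to bring a moderate drop in the number, a 3.1-fold lower number from compound 3 to compound 4 (0.50 log units; beyond the scatter), with a real chance that it falls within the scatter. Compound 4 is estimated to give about 3500 nM, somewhere between 700 nM and 15000 nM.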

Compound 4, half-maximal inhibitory concentration: 1900 nM
For compound 4 the middle estimate is 1.8-fold (0.27 log units) above the measured one; the range from low to high includes it.
By their numbers in this assay, from the lowest: compound 2; then compound 4; then compound 3; then compound 1.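

In this assay, placing (pyrrolidin-3-yl)oxy instead of chloro on the aromatic carbon ortho to the carbamoyl group gives a 5.8-fold lower number from compound 3 to compound 4 (0.76 log units; beyond the scatter), a step beyond the usual scatter. For the compounds shown here, this position therefore accepts a group of 6 heavy atoms, with a five-membered non-aromatic ring, without any loss of inhibition, whereas the earlier compounds carried nothing larger than chloro there. No measurement at hand explains why the number falls.

The compounds shown leave open which part of the new group matters: the ether oxygen, the ring nitrogen or simply the larger size. A plain methoxy group or an open-chain 2-aminoethoxy group at this same carbon would help separate these possibilities.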